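The source may report more compounds than this note shows. Statements on the series, on what has been measured and on what is new or still open speak of the compounds shown alone.

The study covers two measured compounds and a third not yet measured. Compound 1 `COc1ccc(-c2cc3cc(-c4ccc(F)cc4)cc(C(C)=O)c3[nH]2)cc1` was tested in a functional assay on MCF7 cells (Homo sapiens) for cytotoxicity, read by MTT assay, with a stated time of 2 days, tested at 1 uM (a lower number here means a stronger effect, a higher number a weaker effect of the compound at the concentration tested), where compound 1 gives 96.4%. Compound 2 `CC(=O)c1cc(/C=C/c2ccc(F)cc2)cc2cc(-c3ccccc3)[nH]c12` differs from it in more than one place, and in this assay compound 2 gives 72.2%, the lower of the two numbers, a distance from compound 1 that lies beyond the scatter. The two measured compounds differ in several places at once. No single step can be read between them. Compound 3 `COc1ccc(-c2cc3cc(/C=C/c4ccc(F)cc4)cc(C(C)=O)c3[nH]2)cc1` is built from compound 2 by one change: methoxy in place of hydrogen on an aromatic carbon. Going by the values given here, no measured pair shows this change on its own, so the size of its effect in this assay is uncertain. A small step toward a weaker effect is expected, estimated at a number 7.8 percentage points higher from compound 2 to compound 3 (within the scatter). For compound 3 the expected value in this assay is 80%, within a range from 60% to 100%.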

Compound 3, a percentage reported as activity, at one concentration (the size of the read-out at that concentration, not a potency): 97.3%
Beside the measured number, compound 3's estimate is 17.3 percentage points below it; measured number inside the range.
By their numbers in this assay, from the lowest: compound 2; then compounds 1 and 3 (each within the scatter of the next).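

The change from phenyl to 4-methoxyphenyl, with methoxy para to a large group, now has a size of its own in this assay: a number 25.1 percentage points higher from compound 2 to compound 3 (beyond the scatter), toward a weaker effect at the concentration tested. With 4-methoxyphenyl kept, 2-(4-fluorophenyl)ethenyl in place of 4-fluorophenyl on an aromatic carbon gives a number 0.9 percentage points higher from compound 1 to compound 3 (within the scatter), so that exchange shows no readable change here.

Still open, on these data alone, is whether an amine, a hydroxyl or an ethoxy group at this position would shift the number as methoxy does, and whether the methoxy step keeps its size when 4-fluorophenyl replaces 2-(4-fluorophenyl)ethenyl. Nothing available explains the size of the methoxy step.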